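Methyl in Place of Hydrogen: Compound 3 to Compound 4

A few compounds are considered here, and "the series" means these few. Any claim that something is new, unique, unknown or untested is made for them only; others in the source may bear on it.

Of the compounds shown here, three have been measured in a functional assay on SJ-G2 cells (Homo sapiens) for inhibition, read by MTT assay, with a stated time of 72 h; on this read-out lower numbers stand for stronger inhibition of growth and higher numbers for weaker inhibition of growth. Compound 1 `N#C/C(=C\c1c[nH]c2ccccc12)C(=O)c1c[nH]c2ccccc12` gives 13000 nM. Compound 2 `COc1ccc(CNC(=O)/C(C#N)=C/c2ccc[nH]2)cc1` reaches only a limit of the assay, > 50000 nM, so no number is known for it (the limit of > 50000 nM in this assay, at which 1 of the 3 values shown sits). Compound 3 `COc1ccc(CNC(=O)/C(C#N)=C/c2ccco2)cc1` gives 31000 nM, which is the highest of the two numbers; compound 1 stands nearest, with a lower number that lies beyond the scatter. For the measured compounds named here, the only measured step that changes one place is an at least 1.6-fold lower number from compound 2 to compound 3 (0.20 log units; that floor lies within the scatter), and its floor lies within the scatter.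

Compound 4 `COc1ccc(CNC(=O)/C(C#N)=C/c2ccc(C)o2)cc1` differs from compound 3 by methyl in place of hydrogen on an aromatic carbon. Going by the values given here, no measured step adds a methyl to a ring, so none bears directly on this change; the one step that exists swaps an entire five-membered ring and still reaches only the edge of the scatter. Among the compounds with values here, with so small a change and no step that points either way, I expect compound 4 to move no further than the scatter allows, and I estimate for compound 4 the step of a 1.1-fold lower number from compound 3 to compound 4 (0.04 log units; within the scatter). Compound 4 is therefore expected to give about 28000 nM in this assay, most likely between 10000 nM and 70000 nM.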

Compound 4, concentration for 50% growth inhibition: 75000 nM
Estimate against measurement, compound 4: 2.7-fold (0.43 log units) below; measured number outside the range, above it.
By their numbers in this assay, from the lowest: compound 1; then compound 3; then compound 4.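

In this assay, the aromatic carbon next to the ring oxygen proves sensitive to even the smallest addition: methyl in place of hydrogen there gives a 2.4-fold higher number from compound 3 to compound 4 (0.38 log units; beyond the scatter). This is the first step shown that alters a single group on the ring and not the whole ring, and it lies beyond the scatter, whereas the floor of the earlier ring swap, an at least 1.6-fold lower number from compound 2 to compound 3 (0.20 log units; that floor lies within the scatter), lay within it. So one added carbon, with no ring, no hydrogen-bond donors or acceptors and no net charge, moves this pair of compounds towards weaker inhibition of growth, though a single pair cannot establish a wider pattern.

The step from compound 2 to compound 4 cannot be read, because compound 2 stands at a limit of the assay: the limit of > 50000 nM in this assay, at which 1 of the 4 values shown sits. Still open is whether an ethyl group, a methoxy group or a chlorine atom on the same ring carbon would raise the number further or whether an amine there would lower it, and nothing shown tells why the methyl group raises it.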